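Growing the amide substituent on compound 3

This account rests on a few compounds, and the source may have more. Where it says the series, first, only, none or still open, it means among the compounds named here.

Measured compounds in an assay for inhibition of 6-phosphofructo-2-kinase/fructose-2,6-bisphosphatase 3 (Homo sapiens), read by ADP-Glo, with a stated time of 2 h; a higher number here means a weaker inhibitor, a lower number a stronger inhibitor:
compound 1, `Cn1ccc2ccc(-c3cc(Nc4ccccc4S(N)(=O)=O)cc4nccnc34)cc21`, 265 nM
compound 2, `Cn1ccc2ccc(-c3cc(Nc4ccccc4S(=O)(=O)Nc4cncnc4)cc4nccnc34)cc21`, 1690 nM
compound 3, `CNC(=O)c1ccncc1Nc1cc(-c2ccc3ccn(C)c3c2)c2nccnc2c1`, 83 nM

Compound 3 gives the lowest number of the three. Its nearest neighbour is compound 1, reached by a 3.2-fold lower number from compound 1 to compound 3 (0.50 log units; beyond the scatter); compound 2 lies furthest away, and the step of a 6.4-fold higher number from compound 1 to compound 2 (0.80 log units; beyond the scatter) shows what adding a pyrimidin-5-yl onto the sulfonamide nitrogen of compound 1 did.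

Compound 4, `CC(=O)N1CCCC(NC(=O)c2ccncc2Nc2cc(-c3ccc4ccn(C)c4c3)c3nccnc3c2)C1`, has not yet been measured in this assay. The difference from compound 3 is 1-acetylpiperidin-3-yl in place of methyl on an amide-type nitrogen.

Among the measured compounds shown here, no measured step changes the amide nitrogen of compound 3, so nothing bears directly on this move. For the measured compounds named here, the only step of a similar kind is the one from compound 1 to compound 2, where a ring added onto a nitrogen bearing hydrogen gave a modest weakening. Here, a ring enters an amide-type nitrogen that loses only a methyl, which is a different place on a different group, and the acetylpiperidine is not aromatic. On this slim basis a modest step toward a higher number, or none beyond the scatter, is expected: a 1.8-fold higher number from compound 3 to compound 4 (0.26 log units; within the scatter). Compound 4 is therefore estimated at 150 nM, with a range from 50 nM to 450 nM.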

Compound 4, half-maximal inhibitory concentration: 11 nM
Compound 4: middle estimate off by 14-fold (1.13 log units), on the high side; the whole stated range lies above it.
By their numbers in this assay, from the lowest: compound 4; then compound 3; then compound 1; then compound 2.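

In this assay, among the compounds shown here, the change at the amide-type nitrogen gave a 7.5-fold lower number from compound 3 to compound 4 (0.88 log units; beyond the scatter), the first measured change at this place. It shows that this nitrogen accepts far more than a methyl: 1-acetylpiperidin-3-yl, with its six-membered non-aromatic ring and acetyl carbonyl, lowered the number instead of leaving it within the scatter or raising it, so the direction of a 6.4-fold higher number from compound 1 to compound 2 (0.80 log units; beyond the scatter), where a ring was added on a sulfonamide nitrogen, did not carry over to this different group. The compounds offer no independent measurement that bears on why the number fell.

The compounds shown do not separate the contribution of the piperidine ring from that of its acetyl group, and a free piperidine amine, a plain cyclohexyl ring or a longer alkyl chain on the same nitrogen would each bear on that question. They also leave open whether the place of attachment on the ring matters, as 1-acetylpiperidin-4-yl would test, and how much further the substituent can grow before the number rises again.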